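The source may hold more compounds than are shown below. What is called first, only, known or untested is meant among the compounds shown, and "the series" means these compounds.

Measured in a functional assay on MCF7 cells (Homo sapiens) for inhibition, read by MTT assay, with a stated time of 48 h, tested at 10 uM; a higher number here means more inhibition of growth at the concentration tested, a lower number less inhibition of growth:
Compound 1 `Cc1cc(=O)c2c(O)c(CN(C)CC(=O)O)c(O)c([C@H]3CCN(C)C[C@H]3O)c2o1`: 27%
Compound 2 `Cc1cc(=O)c2c(O)c(CN3CCCC3C(=O)O)c(O)c([C@H]3CCN(C)C[C@H]3O)c2o1`: 21%

Compound 2 stands within the scatter of compound 1, and neither can be ranked above the other. Compound 3 `Cc1cc(=O)c2c(O)c(CN3CCCCC3)c(O)c([C@H]3CCN(C)C[C@H]3O)c2o1` differs from compound 2 by piperidin-1-yl in place of 2-carboxypyrrolidin-1-yl on a saturated chain carbon bound to an aromatic carbon. Among the measured compounds shown here, the one measured step, a number 6 percentage points lower from compound 1 to compound 2 (within the scatter), bears only loosely, since both of its groups keep a carboxy group and this change removes it. A step within the scatter is therefore expected in this assay, leaning slightly upward, though the data cannot fix its direction. The expected change is a number 9 percentage points higher from compound 2 to compound 3 (within the scatter). The estimate for compound 3 is 30%, with an expected range of 12% to 55%.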

Compound 3, percent growth inhibition at one concentration: 15%
Compound 3: the middle estimate sits 15 percentage points above what was measured; the measured number falls inside the stated range.
By their numbers in this assay, from the lowest: compounds 3, 2 and 1 (each within the scatter of the next, the first and the last beyond it).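

At the saturated chain carbon bound to an aromatic carbon, piperidin-1-yl in place of 2-carboxypyrrolidin-1-yl gives a number 6 percentage points lower from compound 2 to compound 3 (within the scatter) in this assay. Piperidin-1-yl in place of (carboxymethyl)(methyl)amino gives a number 12 percentage points lower from compound 1 to compound 3 (beyond the scatter) and is the only step here that passes the scatter, so a group without a carboxy group brought no rise in this series of three. The data offer no evidence for a cause of these steps. From the compounds shown here alone, whether morpholin-4-yl or dimethylamino would read differently at this place remains open, as does the effect of a carboxylic acid on a piperidine ring or on a longer chain.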